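Chain lengthening on the shared core: compound 3 to compound 4

The compounds below may be only part of what the source reports. "The series", "measured", "known", "first", "only" and "open" are said of these compounds alone.

Compound 1, `CCCc1ccccc1OS(=O)(=O)c1ccc(NC(=O)NCCCCl)cc1`, gives 13000 nM in a functional assay on HT-29 cells (Homo sapiens) for cytotoxicity, read by sulforhodamine B assay, with a stated time of 48 h; a lower number here means a stronger inhibitor, a higher number a weaker inhibitor.
Compound 2, `CCNC(=O)Nc1ccc(S(=O)(=O)Oc2ccccc2C)cc1`, gives 12000 nM in this assay.
Compound 3, `CCNC(=O)Nc1ccc(S(=O)(=O)Oc2ccccc2CC)cc1`, gives 12000 nM in this assay.

Compound 3 stands level with compound 2, and compound 1 differs from it only within the scatter, so the three numbers sit together. Compound 4, `CCCc1ccccc1OS(=O)(=O)c1ccc(NC(=O)NCC)cc1`, differs from compound 3 by methyl in place of hydrogen on a saturated chain carbon, two bonds along the chain from an aromatic carbon. Within the data shown here, the one measured step that bears on it is the same methyl for hydrogen on a saturated chain carbon bound to an aromatic carbon, which gave no change at the digits printed from compound 2 to compound 3 (within the scatter). On that basis no step beyond the scatter is expected in this assay; the expected step is no change at the digits printed from compound 3 to compound 4 (within the scatter). For compound 4 the estimate is 12000 nM, with a range from 6000 nM to 24000 nM.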

Compound 4, half-maximal inhibitory concentration: 2400 nM
Compound 4: middle estimate off by 5.0-fold (0.70 log units), on the high side; the whole stated range lies above it.
By their numbers in this assay, from the lowest: compound 4; then compounds 2, 3 and 1 (each within the scatter of the next).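

In this assay methyl in place of hydrogen, two bonds along the chain from an aromatic carbon, gives a 5.0-fold lower number from compound 3 to compound 4 (0.70 log units; beyond the scatter) and so ethyl to propyl counts where methyl to ethyl did not. Propyl set against methyl gives a 5.0-fold lower number from compound 2 to compound 4 (0.70 log units; beyond the scatter) as well. Propyl alone does not settle it: hydrogen in place of chloromethyl, two bonds along the chain from an amide-type nitrogen, gives a 5.4-fold lower number from compound 1 to compound 4 (0.73 log units; beyond the scatter) with propyl present in both compounds.

Nothing available here explains these steps. As far as these compounds go, whether a butyl chain in place of propyl goes further stays open, as does the effect of an amine in place of that chloromethyl.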